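Ethylsulfonyl analogue of compound 1: cytotoxicity expectation

This account rests on a few compounds, and the source may have more. Where it says the series, first, only, none or still open, it means among the compounds named here.

Compound 1 `CS(=O)(=O)CCCn1c(Cn2cc(S(C)(=O)=O)c3ccccc32)nc2cc(Cl)ccc21` is assessed in an ADME assay on HEp-2 cells (Homo sapiens) for cytotoxicity, with a stated time of 4 days; a higher number here means that more compound is tolerated, a lower number that less compound is tolerated. Compound 1 there gives a limit rather than a number, > 100000 nM. Compound 2 `CS(=O)(=O)CCCn1c(Cn2cc(S(C)(=O)=O)c3cc(F)ccc32)nc2cc(Cl)ccc21` also reaches only a limit, > 100000 nM. Compound 3 `CS(=O)(=O)CCCn1c(Cn2nc(S(C)(=O)=O)c3ccncc32)nc2cc(Cl)ccc21` likewise sits at a limit, > 100000 nM. Hence the step that the two limits leave unreadable from compound 1 to compound 2 cannot be sized; the available evidence is the limit of > 100000 nM in this assay, at which 3 of the 3 values shown sit. Compound 4 `CCS(=O)(=O)c1cn(Cc2nc3cc(Cl)ccc3n2CCCS(C)(=O)=O)c2ccccc12` differs from compound 1 by methyl in place of hydrogen on a saturated chain carbon bound to a sulfonyl sulfur, methylsulfonyl to ethylsulfonyl. Among the compounds with values here, no measured step addresses this change, and the one step known from compound 1 is unreadable, so no step beyond the scatter is expected, only another limit. The expected value for compound 4 is 150000 nM, with range 60000 nM to 500000 nM. The expected step that the limit leaves unreadable from compound 1 to compound 4 is thus close to none.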

Compound 4, half-maximal cytotoxic concentration: > 100000 nM
Compound 4: only a limit was reported; the forecaster's own chance of this, stated with the estimate: 85%; the middle value does not contradict the limit.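

Compound 1 and compound 4 both stand at a limit in this assay, so no step between them can be read: the limit of > 100000 nM in this assay, at which 4 of the 4 values shown sit.

The compounds shown leave open where any true value lies, and whether methylsulfonyl to ethylsulfonyl alters tolerance at all.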